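The source may hold more compounds than are shown below. What is called first, only, known or untested is meant among the compounds shown, and "the series" means these compounds.

Working notes on the series. Three compounds carry numbers in a functional assay on the whole organism (strain Lewis) with Rattus norvegicus as the target, with a stated time of 24 h, at a dose of 0.3 mg/kg by the oral route (on this read-out lower numbers stand for less inhibition and higher numbers for more inhibition at the one dose given (going by the name of the read-out)), so far. Compound 1 `COc1ccc(COC[C@@H]2CCc3cc([C@H]4CC[C@](N)(CO)C4)ccc3C2)cc1` gives 33%, the second highest of the three, with compound 2 `COc1cccc(CO[C@@H]2CCc3cc([C@H]4CC[C@](N)(CO)C4)ccc3C2)c1` giving 15%, a gap beyond the scatter, and compound 3 `COc1cccc(OC[C@H]2CCc3cc([C@H]4CC[C@](N)(CO)C4)ccc3C2)c1` giving 70%, which stands well beyond the scatter above compound 1. No pair among these three differs in a single place, so no step from one measured compound to another can be isolated.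

Compound 4 `COc1cccc(OC[C@@H]2CCc3cc([C@H]4CC[C@](N)(CO)C4)ccc3C2)c1` is the next compound to be measured in this assay. Against compound 1 the change is 3-methoxyphenyl in place of 4-methoxybenzyl on an oxygen on a saturated carbon. The 3-methoxyphenyl group on oxygen is also the group carried by compound 3, and that compound gave 70%, although its remaining differences from compound 4 leave the transfer uncertain. A step of moderate size upward in this assay is expected, though the scatter allows it to vanish. For compound 4 the estimated inhibition is 42%, within 12% to 72%, so the expected step of a number 9 percentage points higher from compound 1 to compound 4 (within the scatter) is modestly upward.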

Compound 4, a percentage reported as inhibition, in the whole organism at one dose (the size of the read-out at that dose, not a potency): 80%
Compound 4: the middle estimate sits 38 percentage points below what was measured, outside the stated range (above it).
By their numbers in this assay, from the lowest: compound 2; then compound 1; then compounds 3 and 4 (each within the scatter of the next).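

In this assay, going by these compounds alone, the place on an oxygen on a saturated carbon proves sensitive to the group it carries: 3-methoxyphenyl in place of 4-methoxybenzyl gives a number 47 percentage points higher from compound 1 to compound 4 (beyond the scatter), a large step and the first single-place change that can be read. The stereocentre at a saturated ring carbon, by contrast, gives only a number 10 percentage points higher from compound 3 to compound 4 (within the scatter), so at this one dose the read-out does not separate the two configurations that carry 3-methoxyphenyl: the fact that compounds 3 and 4 differ only in the configuration as drawn

The step from 4-methoxybenzyl to 3-methoxyphenyl joins two differences, benzyl against phenyl and 4-methoxy against 3-methoxy, and the compounds shown do not part them. Also open, as far as these compounds go, is how this assay would respond to 4-methoxyphenyl or unsubstituted phenyl on the same oxygen, or to a carboxylic acid or an amine in place of methoxy.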